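The source may report more compounds than this note shows. Statements on the series, on what has been measured and on what is new or still open speak of the compounds shown alone.

Three compounds sharing a core were measured in a functional assay on PC-3 cells (Homo sapiens) for inhibition, read by sulforhodamine B assay, with a stated time of 48 h; on this read-out higher numbers stand for weaker inhibition of growth and lower numbers for stronger inhibition of growth. Compound 1, `COc1ccc(/C=C/C2(C)C=CC(=O)O2)c(OC)c1`, gives 63500 nM. Compound 2, `COc1ccc(/C=C/C2(C)C=CC(=O)O2)cc1OC`, gives 176000 nM, and compound 3, `COc1cc(/C=C/C2(C)C=CC(=O)O2)cc(OC)c1OC`, gives 131000 nM. Compound 1 and compound 2 contain the same atoms joined differently; the difference between the two cores is not broken down here. Compound 1 holds the lowest of the three numbers, and its steps to compound 3 and to compound 2 both lie beyond the scatter.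

Compound 2 and compound 3 differ in one place: methoxy in place of hydrogen on an aromatic carbon. In this assay this gave a 1.3-fold lower number from compound 2 to compound 3 (0.13 log units; within the scatter).

The unmeasured compound 4, `COc1cc(OC)c(/C=C/C2(C)C=CC(=O)O2)c(OC)c1`, differs from compound 1 by the same kind of change: methoxy in place of hydrogen on an aromatic carbon. The surroundings are not the same, though. In compound 3 the entering methoxy stands ortho to a methoxy group, meta to a group of 9 heavy atoms and meta to a methoxy group, whereas in compound 4 it stands ortho to a group of 9 heavy atoms and meta to two methoxy groups.

The expectation for compound 4 rests on compound 2 and compound 3, because a 1.3-fold lower number from compound 2 to compound 3 (0.13 log units; within the scatter) was a small step that stayed within the scatter. A similarly small step is expected from compound 1, namely a 1.2-fold lower number from compound 1 to compound 4 (0.06 log units; within the scatter), with added uncertainty from the different surroundings. Compound 4 is therefore estimated at 55000 nM, expected to fall between 20000 nM and 150000 nM.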

Compound 4, concentration for total growth inhibition: 239000 nM
Estimate against measurement, compound 4: 4.3-fold (0.64 log units) below, outside the stated range (above it).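

In this assay, methoxy in place of hydrogen on an aromatic carbon gave a 3.8-fold higher number from compound 1 to compound 4 (0.58 log units; beyond the scatter), a step that lies beyond the scatter and points towards weaker inhibition of growth. For the compounds shown here, the same change therefore did not carry the same result from one core to the other: the same change on two cores in this assay, a 1.3-fold lower number (0.13 log units; within the scatter) from compound 2 to compound 3 and a 3.8-fold higher number (0.58 log units; beyond the scatter) from compound 1 to compound 4, 5.1-fold (0.70 log units) apart, beyond the scatter of two such steps With only one pair for each core, this does not show what sets the two steps apart, since the methoxy in compound 4 stands ortho to a group of 9 heavy atoms and meta to two methoxy groups, and these two pairs cannot separate that place from the other differences between the cores; nor do they give a rule for any further compound.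

The compounds shown leave open how a group other than methoxy, such as an amine or a hydroxy group, would read in this assay on the same aromatic carbon of compound 1. They also leave open whether a longer chain in place of any of the methoxy groups would follow either of the two steps.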